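This account rests on a few compounds, and the source may have more. Where it says the series, first, only, none or still open, it means among the compounds named here.

Series notes, values from a physicochemical assay for lipophilicity, read by LC-MS, in phosphate buffer, measured as octanol-water partition, with a stated time of 30 min, at pH 7.4, tested at 200 mM; on this read-out higher numbers stand for higher lipophilicity and lower numbers for lower lipophilicity:

- compound 1 `Cc1ccc(Oc2ccc3nc(COc4cccc(C(=O)O)c4)n(C)c3n2)c(C)c1`: 2.3
- compound 2 `Cn1c(COc2cccc(C(=O)O)c2)nc2cnc(Oc3ccc4c(c3)CCC4)cc21`: 1.6
- compound 3 `Cn1c(COc2cccc(C(=O)O)c2)nc2ccc(Oc3cc(Cl)ccn3)cc21`: 1.2

Compound 3 has the lowest number of the three, at 1.2. Compound 2, at 1.6, and compound 1, at 2.3, both stand higher than compound 3 by more than the scatter.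

The next compound to read in this assay is compound 4 `Cn1c(COc2cccc(C(=O)O)c2)nc2ccc(Oc3ncccc3F)cc21`. It departs from compound 3 at one place: 3-fluoropyridin-2-yl in place of 4-chloropyridin-2-yl on an oxygen on an aromatic ring. In words, 3-fluoropyridin-2-yl stands in place of 4-chloropyridin-2-yl on an oxygen on an aromatic ring.

Within the data shown here, no pair of measured compounds differs in one place only, so the series offers no measured step to carry over to this change. The expectation therefore rests on compound 3 at 1.2 and on the structural change itself, and the range is kept wide. The expected result is a modest fall, close to the edge of the scatter rather than clearly beyond it, estimated as a number 0.30 log units lower from compound 3 to compound 4 (within the scatter). A step in the other direction is not excluded by anything measured so far.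

For compound 4 the estimated value is 0.9, with an expected range from 0.5 to 1.3.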

Compound 4, distribution coefficient: 0.6
Estimate against measurement, compound 4: 0.30 log units above; the range from low to high includes it.
By their numbers in this assay, from the lowest: compound 4; then compound 3; then compound 2; then compound 1.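

In this assay, among these compounds, the exchange of 4-chloropyridin-2-yl for 3-fluoropyridin-2-yl, on an oxygen on an aromatic ring, gives the first one-place step, and it reads a number 0.60 log units lower from compound 3 to compound 4 (beyond the scatter) on this measure. The step shows that this position is not indifferent to the identity of the pyridinyl group: the read-out moves by more than the scatter even though the counts of heavy atoms, hydrogen-bond donors and hydrogen-bond acceptors stay the same on both sides of the change. Nothing at hand explains the size or direction of this step, so it stands as an observation on this one pair.

The two groups differ both in the halogen and in the ring number at which it stands, so this single step cannot divide its size between those two differences, and 3-chloropyridin-2-yl or 4-fluoropyridin-2-yl would be the groups that separate them. Also open, as far as these compounds go, is whether the same step would hold with a different group at this place, such as a pyridinyl ring carrying a nitrile or a methoxy group, or on another version of the shared core.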